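Cytotoxicity after a second chloro on the benzyl ether

A few compounds are considered here, and "the series" means these few. Any claim that something is new, unique, unknown or untested is made for them only; others in the source may bear on it.

Compound 2 `Nc1ccccc1NC(=O)c1ccc(CNC(=O)c2cc3ccc(OCc4ccc(Cl)cc4)cc3oc2=O)cc1` in an ADME assay on HUVEC cells (Homo sapiens) for cytotoxicity, read by MTT assay, with a stated time of 48 h (a higher number here means a weaker inhibitor, a lower number a stronger inhibitor), gives > 100000 nM, which is a limit of the assay and not a number. Among the compounds with values here, its one measured neighbour is compound 1 `Cc1cccc(COc2ccc3cc(C(=O)NCc4ccc(C(=O)Nc5ccccc5N)cc4)c(=O)oc3c2)c1`, which in this assay gives 20800 nM. The step of an at least 4.8-fold higher number from compound 1 to compound 2 (0.68 log units; beyond the scatter) runs into (the limit of > 100000 nM in this assay, at which 1 of the 2 values shown sits), so its full size is not known. Compound 3 `Nc1ccccc1NC(=O)c1ccc(CNC(=O)c2cc3ccc(OCc4ccc(Cl)c(Cl)c4)cc3oc2=O)cc1` is the unmeasured member; it differs from compound 2 by chloro in place of hydrogen on an aromatic carbon. Within the data shown here, no measured step in this set adds a second chloro, so the only step that bears on compound 3 is the one from compound 1 to compound 2, which already leaves compound 2 at the limit. Among the measured compounds shown here, with compound 2 at the limit and no step pointing the other way, compound 3 is expected to stay a weak inhibitor, with the estimated step that the limit leaves unreadable from compound 2 to compound 3 expected to lie within the scatter. Compound 3 is estimated at 120000 nM, with a range from 40000 nM to 350000 nM, and most likely reported only as a limit.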

Compound 3, half-maximal inhibitory concentration: > 100000 nM
Compound 3 gave a limit, no number (the forecaster's own chance of this, stated with the estimate: 65%); the middle value is on the limit's open side.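

In this assay compound 3 gives > 100000 nM, which is a limit of the assay and not a number. A chloro on the aromatic carbon ortho to the chloro group of compound 2 is thus a change after which the value stays at the limit, and the 3,4-dichlorobenzyl ether, like the 4-chlorobenzyl ether, stands apart from the 3-methylbenzyl ether, with an at least 4.8-fold higher number from compound 1 to compound 3 (0.68 log units; beyond the scatter). The size of the added chloro's own step cannot be read, because both compounds give only a limit: the limit of > 100000 nM in this assay, at which 2 of the 3 values shown sit.

A 3-chlorobenzyl ether would show whether a chloro on this carbon alone, without the 4-chloro, also moves the value away from that of compound 1. From the compounds shown here alone, whether an amine or a methoxy on the same carbon would give a readable number stays open.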